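Thiourea series: from compound 3 to compound 4

A few compounds are considered here, and "the series" means these few. Any claim that something is new, unique, unknown or untested is made for them only; others in the source may bear on it.

Measured so far in an ADME assay on BHK cells (Mesocricetus auratus) for cytotoxicity, read by MTT assay, with a stated time of 96 h (on this read-out lower numbers stand for higher toxicity in this test and higher numbers for lower toxicity in this test), for three compounds
- compound 1 `CC[C@H]1CC[C@H](c2ccc(NC(=S)Nc3cccc(C(F)(F)F)c3)cc2)CC1` gives 10000 nM
- compound 2 `Fc1ccc(NC(=S)Nc2cccc(C(F)(F)F)c2)cc1Cl` gives 10000 nM
- compound 3 `Fc1ccc(NC(=S)Nc2cccc(C(F)(F)F)c2)cc1` gives 26000 nM

Compound 3 stands highest of the three, and both others lie beyond the scatter from it. Compound 4 `FC(F)(F)c1cccc(NC(=S)Nc2ccccc2Br)c1` carries 2-bromophenyl in place of 4-fluorophenyl on an amide-type nitrogen. Among the compounds with values here, no measured step makes this exact change, but two bear on it. Hydrogen in place of chloro on an aromatic carbon gives a 2.6-fold higher number from compound 2 to compound 3 (0.41 log units; beyond the scatter) and fluoro in place of 4-ethylcyclohexyl on an aromatic carbon gives a 2.6-fold higher number from compound 1 to compound 3 (0.41 log units; beyond the scatter) as well. Both steps are modest and both end at compound 3 with the higher number, and neither of the other two compounds goes against this. A modest step to a lower number is therefore expected in this assay here. There are no measured data on a bromo group, so the range stays wide. The estimated step is a 2.2-fold lower number from compound 3 to compound 4 (0.34 log units; beyond the scatter) in this direction. Compound 4 is estimated at 12000 nM with an expected range from 5000 nM to 30000 nM for now.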

Compound 4, half-maximal cytotoxic concentration: 59000 nM
The estimate for compound 4 lay 4.9-fold (0.69 log units) below the measured number; measured number outside the range, above it.
By their numbers in this assay, from the lowest: compounds 1 and 2 (each within the scatter of the next); then compound 3; then compound 4.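

In this assay, 2-bromophenyl in place of 4-fluorophenyl on an amide-type nitrogen gives a 2.3-fold higher number from compound 3 to compound 4 (0.36 log units; beyond the scatter), so compound 3 no longer marks the top of the series. The earlier steps shown here were changes on an aromatic carbon and both ended at compound 3; this one shows that replacing the whole aryl group on this nitrogen, with the heavy-atom count unchanged and no hydrogen-bond donors or acceptors in either group, can still move the number upward. No measured evidence bears on why this change raises the number.

The step changes both the halogen and where it sits, and the compounds shown do not separate the two. On these data alone, how an amine or a carboxylic acid in place of the bromo group would read in this assay also remains open.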